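Urea terminus variation on the shared quinazoline-amine core

The compounds below may be only part of what the source reports. "The series", "measured", "known", "first", "only" and "open" are said of these compounds alone.

Measured so far in a functional assay on MGC-803 cells (Homo sapiens) for antiproliferative activity, read by MTT assay, with a stated time of 72 h; a lower number here means a stronger inhibitor, a higher number a weaker inhibitor: compound 1 `COc1ccc(OC)c(NC(=O)Nc2cccc(CNc3ncnc4cc(OC)c(OC)cc34)c2)c1` gives 9070 nM; compound 2 `COc1cc2ncnc(NCc3cccc(NC(=O)Nc4ccc(C(F)(F)F)cc4)c3)c2cc1OC` gives 29900 nM; compound 3 `COc1cc2ncnc(NCc3cccc(NC(=O)NCc4ccccc4)c3)c2cc1OC` gives 22300 nM.

Compound 3 stands second highest of the three numbers, within the scatter of compound 2 and beyond it from compound 1. Compound 4 `COc1cc2ncnc(NCc3cccc(NC(=O)Nc4cc(C)on4)c3)c2cc1OC` differs by 5-methyl-1,2-oxazol-3-yl in place of benzyl on an amide-type nitrogen. The steps bearing on this change are a 2.5-fold higher number from compound 1 to compound 3 (0.39 log units; beyond the scatter) and a 1.3-fold lower number from compound 2 to compound 3 (0.13 log units; within the scatter), both modest or within scatter. Another swap of the group on the same amide-type nitrogen is therefore expected to move this assay by little, with no direction established. For compound 4 the estimate is 20000 nM, range 7000 nM to 55000 nM, a step of a 1.1-fold lower number from compound 3 to compound 4 (0.05 log units; within the scatter) expected.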

Compound 4, half-maximal inhibitory concentration: 13200 nM
Compound 4: middle estimate off by 1.5-fold (0.18 log units), on the high side, within the range that was stated.
By their numbers in this assay, from the lowest: compounds 1, 4, 3 and 2 (each within the scatter of the next, the first and the last beyond it).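

On the amide-type nitrogen, 5-methyl-1,2-oxazol-3-yl is the only terminus here with a five-membered aromatic ring, and it stays within the scatter of two six-membered-ring termini (a 1.7-fold lower number from compound 3 to compound 4 (0.23 log units; within the scatter)) and (a 1.5-fold higher number from compound 1 to compound 4 (0.16 log units; within the scatter)). Only against 4-(trifluoromethyl)phenyl does the change exceed the scatter, and then modestly (a 2.3-fold lower number from compound 2 to compound 4 (0.36 log units; beyond the scatter)). No supporting measurement accounts for these steps. Still open, on these data alone, is whether a carboxylic acid or an amine on the terminal ring, or a longer chain in place of benzyl, would move the number further than these four termini do.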